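A few compounds are considered here, and "the series" means these few. Any claim that something is new, unique, unknown or untested is made for them only; others in the source may bear on it.

Compound 1 `O=c1[nH]c(=O)n([C@H]2C[C@H](O)[C@@H](CO)O2)cc1CO` and compound 2 `O=c1[nH]c(=O)n([C@H]2C[C@H](O)[C@@H](CO)O2)cc1C#CCCCO` share one core and differ only at a single carbon of the six-membered aromatic ring. In an ADME assay on L1210/0 cells (Mus musculus) for cytotoxicity, with a stated time of 48 h (a higher number here means a weaker inhibitor, a lower number a stronger inhibitor), compound 1 gives 9180 nM. For compound 2 this assay gives only a limit, > 200000 nM, namely (the limit of > 200000 nM in this assay, at which 1 of the 2 values shown sits). For the measured compounds named here, the one measured step, an at least 21-fold higher number from compound 1 to compound 2 (1.33 log units; beyond the scatter), was large and toward weaker inhibition. Compound 3 `O=c1[nH]c(=O)n([C@H]2C[C@H](O)[C@@H](CO)O2)cc1C1SCCS1` alters that same carbon again: a group of 5 heavy atoms (3 carbon, 2 sulfur; one five-membered non-aromatic ring with 2 hetero atoms) in place of a group of 6 heavy atoms (5 carbon, 1 oxygen; no ring), on an aromatic carbon. Going by the values given here, only that single step bears on this change, so the direction and size for compound 3 remain uncertain, with a real chance of another limit. Compound 3 is expected to give about 150000 nM, between 20000 nM and 400000 nM. That expectation corresponds to an at least 1.3-fold lower number from compound 2 to compound 3 (0.12 log units; that floor lies within the scatter).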

Compound 3, half-maximal inhibitory concentration: > 200000 nM
Compound 3 ended at the assay's limit; the forecaster's own chance of this, stated with the estimate: 55%; middle value at least 1.3-fold (0.12 log units) from the limit.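

Replacing hydroxymethyl with a group holding a five-membered non-aromatic ring with 2 hetero atoms gives an at least 21-fold higher number from compound 1 to compound 3 (1.33 log units; beyond the scatter) in this assay. A large rise at this aromatic carbon is therefore not confined to the 5-hydroxypent-1-yn-1-yl chain, although these are the only two replacements shown. The step between the other two compounds cannot be read: the limit of > 200000 nM in this assay, at which 2 of the 3 values shown sit.

As far as these compounds go, it remains open how far the true values of compound 2 and compound 3 lie beyond that limit. From the compounds shown here alone, it is also open whether an amine or a carboxylic acid on this carbon would keep the number near that of compound 1.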